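Nitro Substitution in a Sulfonamide Benzamide Series: Cytotoxicity

The source may hold more compounds than are shown below. What is called first, only, known or untested is meant among the compounds shown, and "the series" means these compounds.

Compound 1 `CCS(=O)(=O)Nc1ccc(NC(=O)c2ccc(Cl)cc2)cc1C` and compound 2 `CCS(=O)(=O)Nc1ccc(NC(=O)c2ccc(Cl)c([N+](=O)[O-])c2)cc1C` share one core; compound 3 `CS(=O)(=O)Nc1ccc(NC(=O)c2ccc(Cl)cc2)cc1Cl` and compound 4 `CS(=O)(=O)Nc1ccc(NC(=O)c2ccc(Cl)c([N+](=O)[O-])c2)cc1Cl` share another, and the difference between the two cores is not broken down here. In an ADME assay on HEK293 cells (Homo sapiens) for cytotoxicity, read by MTT assay, with a stated time of 48 h (a higher number here means a weaker inhibitor, a lower number a stronger inhibitor), compound 1 gives 125000 nM, compound 2 gives 144000 nM and compound 3 gives 167000 nM. The change from compound 1 to compound 2 is nitro in place of hydrogen on an aromatic carbon, and this change gave a 1.2-fold higher number from compound 1 to compound 2 (0.06 log units; within the scatter). The change from compound 3 to compound 4 is nitro in place of hydrogen on an aromatic carbon, the same change at the same place. Compound 4 has not yet been measured. The earlier step stayed within the scatter, so a step of similar size is expected: a 1.1-fold higher number from compound 3 to compound 4 (0.06 log units; within the scatter). For compound 4 the expected value in this assay is 190000 nM, estimated to fall between 100000 nM and 350000 nM.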

Compound 4, half-maximal inhibitory concentration: 204000 nM
For compound 4 the middle estimate is 1.1-fold (0.03 log units) below the measured one; measured number inside the range.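

In this assay, nitro in place of hydrogen on an aromatic carbon gives a 1.2-fold higher number from compound 3 to compound 4 (0.09 log units; within the scatter), and the two cores agree: the same change on two cores in this assay, a 1.2-fold higher number (0.06 log units; within the scatter) from compound 1 to compound 2 and a 1.2-fold higher number (0.09 log units; within the scatter) from compound 3 to compound 4, 1.1-fold (0.03 log units) apart, within the scatter of two such steps. Within this series, the change therefore carries across these two cores without a detectable difference between its steps. Neither step stands clear of the scatter, so the pair does not show that the nitro group itself alters the read-out, nor how the change would behave on any other core.

Open, going by these compounds, is whether an amine or a carboxylic acid in the same place, ortho to a chloro group, would give a step beyond the scatter. Also open, on these data alone, is what a longer chain on the sulfonamide would do.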